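Replacing an Aromatic Ring with a Benzyl Group

The compounds below may be only part of what the source reports. "The series", "measured", "known", "first", "only" and "open" are said of these compounds alone.

Compound 1 `C=C(Br)C(=O)Nc1cccc(-c2cn3nc(-c4ccc(C)cc4)sc3n2)c1` and compound 2 `COc1ccc(-c2csc3nc(-c4cccc(N)c4)cn23)cc1` were both tested in a functional assay on FM3A cells (Mus musculus) for inhibition, read by cell counting, with a stated time of 2 days; on this read-out higher numbers stand for weaker inhibition and lower numbers for stronger inhibition. Compound 1 gives 1200 nM, while compound 2 gives 11000 nM. Compound 1 therefore stands as the lower of the two numbers, with compound 2 a long way above it; the two compounds differ in more than one place, so their gap is noted here only as what the two values show.

Compound 3 `C=C(Br)C(=O)Nc1cccc(-c2cn3nc(Cc4ccccc4)sc3n2)c1` has not yet been measured in this assay. It differs from compound 1 in one place: benzyl in place of 4-methylphenyl on an aromatic carbon. Among the measured compounds shown here, no measured pair in this set shows what such a change does, so the size of the step is open. A modest shift is expected, most likely toward a somewhat weaker result, but one that may well stay near the usual scatter of the measurement.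

On that basis, compound 3 is estimated to give 2500 nM, with a range from 800 nM to 8000 nM. The step this estimate means, a 2.1-fold higher number from compound 1 to compound 3 (0.32 log units; beyond the scatter), is expected to be small.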

Compound 3, half-maximal inhibitory concentration: 3000 nM
Compound 3: middle estimate off by 1.2-fold (0.08 log units), on the low side; the measured number falls inside the stated range.
By their numbers in this assay, from the lowest: compound 1; then compound 3; then compound 2.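

Among the compounds shown here, this is the first change at this position with a measured outcome, and it is a swap between two groups of the same atoms, with the aromatic ring joined to the core directly in 4-methylphenyl and through a carbon in benzyl. In this assay, this rearrangement gives a 2.5-fold higher number from compound 1 to compound 3 (0.40 log units; beyond the scatter), so the number moves beyond the usual scatter, but only modestly, and inhibition of the same general order remains with the ring set apart from the core. Nothing measured here explains why the number shifts, and these results alone give no cause for the step.

The swap changes two things at once, removing the methyl group from the ring and adding a carbon link to the core, so the compounds shown cannot say how much of the step belongs to each, and a plain phenyl group or a 4-methylbenzyl group at this position would help to separate them. Also open, going by these compounds, is how a longer chain, such as 2-phenylethyl, or a group without an aromatic ring, such as an amine, would fare at this position.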